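The compounds below may be only part of what the source reports. "The series", "measured", "known", "first", "only" and "open" are said of these compounds alone.

In an assay on CHO cells for antagonist activity at transient receptor potential cation channel subfamily V member 1 (Homo sapiens), read by FLIPR (on this read-out higher numbers stand for weaker inhibition and lower numbers for stronger inhibition), three compounds have been measured, all sharing a core in which the substituent on the aromatic carbon varies. Compound 1 `CC1CCN(c2cc(C(F)(F)F)ccc2CNC(=O)C(C)c2ccc(NS(C)(=O)=O)c(F)c2)CC1` gives 0.9 nM. Compound 2 `CC(C(=O)NCc1ccc(C(F)(F)F)cc1N1CCN(C2CCCCC2)CC1)c1ccc(NS(C)(=O)=O)c(F)c1` gives 13.8 nM. Compound 3 `CC(C)CCOc1cc(C(F)(F)F)ccc1CNC(=O)C(C)c1ccc(NS(C)(=O)=O)c(F)c1` gives 0.5 nM, the lowest of the three numbers; its nearest neighbour is compound 1, and the gap a 1.8-fold lower number from compound 1 to compound 3 (0.26 log units; within the scatter) lies within the scatter, whereas the gap a 28-fold lower number from compound 2 to compound 3 (1.44 log units; beyond the scatter) is beyond it.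

Compound 4 `CC(C(=O)NCc1ccc(C(F)(F)F)cc1OC1CCCC1)c1ccc(NS(C)(=O)=O)c(F)c1` has not yet been measured in this assay. It differs from compound 3 by cyclopentyl in place of isopentyl on an oxygen on an aromatic ring. Within the data shown here, no measured step touches this kind of change: the steps of a 15-fold higher number from compound 1 to compound 2 (1.19 log units; beyond the scatter), a 1.8-fold lower number from compound 1 to compound 3 (0.26 log units; within the scatter) and a 28-fold lower number from compound 2 to compound 3 (1.44 log units; beyond the scatter) all exchange the whole substituent on the aromatic carbon, including the oxygen or nitrogen through which it is attached, while here the oxygen and the count of heavy atoms stay the same and only the shape of the five-carbon group changes. The large steps involving compound 2 therefore say little about compound 4, and the small step from compound 1 to compound 3 suggests that this position tolerates variation.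

For compound 4 the expected step is a 1.6-fold higher number from compound 3 to compound 4 (0.20 log units; within the scatter), that is, none beyond the scatter. Compound 4 is thus estimated at 0.8 nM, with a range from 0.3 nM to 2.5 nM.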

Compound 4, inhibition constant: 0.6 nM
Compound 4: the middle estimate sits 1.3-fold (0.12 log units) above what was measured; low and high end bracket the measured number.
By their numbers in this assay, from the lowest: compounds 3, 4 and 1 (each within the scatter of the next); then compound 2.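

In this assay, among these compounds, cyclopentyl in place of isopentyl on the oxygen gives a 1.2-fold higher number from compound 3 to compound 4 (0.08 log units; within the scatter), the first step here that changes only the group on that oxygen, and it does not separate the ring from the branched chain of the same five carbons. Cyclopentyloxy in place of 4-methylpiperidin-1-yl gives a 1.5-fold lower number from compound 1 to compound 4 (0.18 log units; within the scatter), while cyclopentyloxy in place of 4-cyclohexylpiperazin-1-yl gives a 23-fold lower number from compound 2 to compound 4 (1.36 log units; beyond the scatter), so among the four compounds only compound 2 stands apart, and the tolerance at this position now covers a ring on the oxygen as well as a chain. Nothing available gives a reason for either the tolerance or the large gap to compound 2.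

From the compounds shown here alone, it remains open how far the group on the oxygen can change before the number moves, for instance with a phenyl ring, a longer chain such as octyl, or a chain ending in a dimethylamino group. Going by these compounds, it is also open whether the large steps from compound 2 belong to the cyclohexyl group or to the piperazine itself, which a piperazine carrying only a methyl group could help to separate.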